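This account rests on a few compounds, and the source may have more. Where it says the series, first, only, none or still open, it means among the compounds named here.

Compound 1 `CC1=C(C(=O)Nc2ccc([N+](=O)[O-])cc2)C(c2ccc(Br)cc2)N=C(SCc2ccccc2)N1`: 3.6%
Compound 2 `CC1=C(C(=O)Nc2ccc([N+](=O)[O-])cc2)C(c2ccc(Br)cc2)N=C(SCc2cccc(Cl)c2)N1`: 2.6%

In a functional assay on the whole organism (artery, strain albino) with Rattus norvegicus as the target, with a stated time of 30 min, at a dose of 10 mg/kg by the oral route (a higher number here means more inhibition at the dose given (going by the name of the read-out), a lower number less inhibition), compound 1 gives 3.6%, and compound 2 gives 2.6%. The step of a number 1 percentage points lower from compound 1 to compound 2 (within the scatter) lies within the scatter, so on these numbers compound 1 and compound 2 stand as equals, both low. Compound 3 `CC1=C(C(=O)Nc2ccc([N+](=O)[O-])cc2)C(c2cccc([N+](=O)[O-])c2)N=C(SCc2ccccc2)N1` differs from compound 1 by 3-nitrophenyl in place of 4-bromophenyl on a saturated ring carbon. Going by the values given here, no measured step touches that saturated ring carbon; the only measured step, a number 1 percentage points lower from compound 1 to compound 2 (within the scatter), concerns another place and was within the scatter. Compound 3 is therefore expected to stay low, with a step of a number 0.4 percentage points higher from compound 1 to compound 3 (within the scatter) not beyond the scatter. The estimate for compound 3 is 4%, between 0% and 12%.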

Compound 3, a percentage reported as inhibition, in the whole organism at one dose (the size of the read-out at that dose, not a potency): 4.1%
The estimate for compound 3 lay 0.1 percentage points below the measured number; the measured number falls inside the stated range.
By their numbers in this assay, from the lowest: compounds 2, 1 and 3 (each within the scatter of the next).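

In this assay, 3-nitrophenyl in place of 4-bromophenyl on the saturated ring carbon gives a number 0.5 percentage points higher from compound 1 to compound 3 (within the scatter), so this first change at that position separates the two compounds no more than repeat measurements would. Two phenyl groups carrying different substituents at different ring positions therefore read alike here, and both stay low. No measurement at hand bears on why this is so.

From the compounds shown here alone, whether a plain phenyl, a cyclohexyl group or an amine-bearing chain on this carbon would raise the inhibition remains open. So does whether any change to the shared core can lift the number beyond the scatter.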